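The source may hold more compounds than are shown below. What is called first, only, known or untested is meant among the compounds shown, and "the series" means these compounds.

Measured so far in a functional assay on CAKI-1 cells (Homo sapiens) for inhibition, read by sulforhodamine B assay, with a stated time of 48 h; a higher number here means a weaker inhibitor of growth, a lower number a stronger inhibitor of growth:
Compound 1 `Cc1ccc(NC(=O)/C=C/c2ccccc2)c(C(N)=O)c1`: 8920 nM
Compound 2 `NC(=O)c1cc(Br)ccc1NC(=O)/C=C/c1ccccc1`: 1340 nM

Compound 2, at 1340 nM, holds the lower of the two numbers, and compound 1 gives 8920 nM. The next compound is compound 3 `NC(=O)c1cc(I)ccc1NC(=O)/C=C/c1ccccc1`, and the change is iodo in place of bromo on an aromatic carbon, meta to a carbamoyl group and para to a large group. Going by the values given here, one measured step bears on this, a 6.7-fold lower number from compound 1 to compound 2 (0.82 log units; beyond the scatter), a modest step beyond the scatter, where bromo replaced methyl on an aromatic carbon. Among the compounds with values here, no measured compound carries iodo, so this is a weak guide. In this assay, a small further fall in the number is expected, possibly no larger than the scatter. The expected change is a 1.3-fold lower number from compound 2 to compound 3 (0.13 log units; within the scatter). For compound 3 the estimated value is 1000 nM, with an expected range from 400 nM to 2600 nM.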

Compound 3, concentration for 50% growth inhibition: 648 nM
Estimate against measurement, compound 3: 1.5-fold (0.19 log units) above; the measured number falls inside the stated range.
By their numbers in this assay, from the lowest: compound 3; then compound 2; then compound 1.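

In this assay, going by these compounds alone, the position meta to a carbamoyl group and para to a large group still responds after methyl has gone: iodo in place of bromo gives a 2.1-fold lower number from compound 2 to compound 3 (0.32 log units; beyond the scatter) and so goes beyond the scatter, which the single earlier step could not show. Within the data shown here, measured against the methyl compound, iodo gives a 14-fold lower number from compound 1 to compound 3 (1.14 log units; beyond the scatter) and so a large step where bromo gave only a modest one, and across these three compounds the number falls in the order methyl, bromo, iodo with no compound going against it. Nothing measured here accounts for this order.

The compounds shown leave open how chloro, fluoro, methoxy, a nitrile or an amine would stand at this position, so the order rests on three groups only. They also leave open whether the iodo gain would hold with a substituent on the far phenyl ring, as all three compounds keep that ring bare.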